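Working notes: adding an amino group to compound 2

A few compounds are considered here, and "the series" means these few. Any claim that something is new, unique, unknown or untested is made for them only; others in the source may bear on it.

Measured so far in a functional assay on MOLT-4 cells (Homo sapiens) for antiproliferative activity (on this read-out higher numbers stand for weaker inhibition and lower numbers for stronger inhibition), on two compounds
- compound 1 `OCC1CCCC1n1cnc2c(Cl)ncnc21` gives 19 ug/mL
- compound 2 `CC1(C)[C@@H](Cn2cnc3c(Cl)ncnc32)CC[C@@]1(C)CO` gives 3.8 ug/mL

In this assay compound 2 at 3.8 ug/mL holds the lower of the two numbers. Compound 1 at 19 ug/mL sits above it, and that gap lies beyond the scatter. The two differ in more than one place, so their gap says nothing about a single change.

Compound 3 `CC1(C)[C@@H](Cn2cnc3c(Cl)nc(N)nc32)CC[C@@]1(C)CO` is not yet measured. It departs from compound 2 at one place only (amino in place of hydrogen on an aromatic carbon), with amino in place of hydrogen on an aromatic carbon, between two ring nitrogen atoms and meta to the chloro group.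

Among the compounds with values here, no measured pair shows this change, so neither its size nor its direction can be read from the data. The expectation is therefore no step beyond the scatter, anchored on compound 2 at 3.8 ug/mL and held with a wide margin. The expected step is a 1.1-fold higher number from compound 2 to compound 3 (0.02 log units; within the scatter) and remains an estimate only. For compound 3 the estimated value is 4 ug/mL with an expected range from 1.2 ug/mL to 14 ug/mL in this assay when measured.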

Compound 3, half-maximal inhibitory concentration: 13.2 ug/mL
Compound 3: the middle estimate sits 3.3-fold (0.52 log units) below what was measured; low and high end bracket the measured number.
By their numbers in this assay, from the lowest: compound 2; then compounds 3 and 1 (each within the scatter of the next).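

In this assay, the series now has its first comparison that differs in one place only: a 3.5-fold higher number from compound 2 to compound 3 (0.54 log units; beyond the scatter), with amino in place of hydrogen on the aromatic carbon between two ring nitrogen atoms and meta to a chloro group. The number rises with this change, which means weaker inhibition, so this position is not silent in this assay, something the gap between the two earlier compounds could not show. No measurement at hand bears on why the number moves in this direction.

As far as these compounds go, this single pair gives the direction for amino alone, so it remains open whether a methyl group, a hydroxyl group or a methylamino group on the same carbon would raise the number as well, leave it within the scatter or lower it. From the compounds shown here alone, it also remains open whether amino in place of hydrogen would give a step of similar size and direction on the core of compound 1, which carries a different group on the ring nitrogen.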